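The source may report more compounds than this note shows. Statements on the series, on what has been measured and on what is new or still open speak of the compounds shown alone.

Compound 1 `CC(=O)N1CCC(C(=O)N2C[C@H](C(=O)N(C)C(C)(C)c3cc(C(F)(F)F)cc(C(F)(F)F)c3)[C@@H](c3ccc(F)cc3C)C2)CC1`, compound 2 `CN(Cc1cc(C(F)(F)F)cc(C(F)(F)F)c1)C(=O)[C@H]1CN(C(=O)NC2CCCCC2)C[C@@H]1c1ccccc1` and compound 3 `CC(C)(C)OC(=O)N1C[C@H](C(=O)NCc2cc(C(F)(F)F)cc(C(F)(F)F)c2)[C@@H](c2ccccc2)C1` were all tested in an assay on CHO cells for displacement of a labelled ligand from Substance-P receptor (Homo sapiens); a higher number here means a weaker inhibitor, a lower number a stronger inhibitor. Compound 1 gives 0.05 nM, compound 2 gives 0.79 nM, and compound 3 gives 142 nM. Compound 2 therefore stands in the middle of the three, separated from each neighbour by more than the usual scatter. Compound 4 `CN(Cc1cc(C(F)(F)F)cc(C(F)(F)F)c1)C(=O)[C@H]1CN(C(=O)c2cnccn2)C[C@@H]1c1ccccc1` has not yet been measured in this assay; it differs from compound 2 in a single place: pyrazin-2-yl in place of cyclohexylamino on a carbonyl carbon. Going by the values given here, no measured pair here tests that same change, so the expected step of a 1.9-fold higher number from compound 2 to compound 4 (0.28 log units; within the scatter) rests only on compound 2 with its 0.79 nM and is taken as a modest rise in the number, about at the edge of the scatter. Compound 4 is estimated at 1.5 nM, most likely between 0.3 nM and 8 nM.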

Compound 4, half-maximal inhibitory concentration: 0.74 nM
Estimate against measurement, compound 4: 2.0-fold (0.31 log units) above; the measured number falls inside the stated range.
By their numbers in this assay, from the lowest: compound 1; then compounds 4 and 2 (each within the scatter of the next); then compound 3.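

On the carbonyl carbon, pyrazin-2-yl in place of cyclohexylamino gives a 1.1-fold lower number from compound 2 to compound 4 (0.03 log units; within the scatter) in this assay. This position therefore accepts an aromatic ring with 2 hetero atoms and no hydrogen-bond donor as well as a non-aromatic carbon ring attached through an amino group carrying a donor, so that donor is not needed for a number at this level. Nothing measured here explains this match. From the compounds shown here alone, whether a simple amine or a carboxylic acid on that carbonyl carbon would hold the number at this level stays open, as does whether the same change would read alike on the core of compound 1.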